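Swapping a propyl chain for 3,4-dichlorophenyl in compound 1

The source may hold more compounds than are shown below. What is called first, only, known or untested is meant among the compounds shown, and "the series" means these compounds.

Compound 1 `CCCCN(CC)c1cc(C)nc2c(-c3cnc(N(C)C)cc3C)c(C)nn12` gives 2.6 nM in an assay on CHO cells for binding affinity to corticotropin-releasing factor receptor 1 (Homo sapiens); on this read-out lower numbers stand for stronger inhibition and higher numbers for weaker inhibition. Compound 2 `CCCN(CC1CC1)c1cc(C)nc2c(-c3cnc(N(C)C)cc3C)c(C)nn12` gives 2.6 nM in this assay, so compound 1 stands level with compound 2 at the digits shown, the step of no change at the digits printed from compound 1 to compound 2 (within the scatter) lying within the scatter. Compound 3 `CCN(Cc1ccc(Cl)c(Cl)c1)c1cc(C)nc2c(-c3cnc(N(C)C)cc3C)c(C)nn12` has not yet been measured. It differs from compound 1 in one place: 3,4-dichlorophenyl in place of propyl on a saturated chain carbon bound to a nitrogen on an aromatic ring. Among the compounds with values here, the only measured step at this nitrogen, no change at the digits printed from compound 1 to compound 2 (within the scatter), exchanged one pair of saturated chains for another and left the reading unchanged. Within the data shown here, no measured compound carries an aromatic ring on this chain, so the data say nothing direct about a 3,4-dichlorophenyl there. The step of a 1.5-fold higher number from compound 1 to compound 3 (0.19 log units; within the scatter) is therefore expected to be small, with a wide range around it. Compound 3 is estimated at 4 nM in this assay, between 1 nM and 20 nM.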

Compound 3, inhibition constant: 2.5 nM
The estimate for compound 3 lay 1.6-fold (0.20 log units) above the measured number; the measured number falls inside the stated range.
By their numbers in this assay, from the lowest: compounds 3, 1 and 2 (each within the scatter of the next).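

Exchanging propyl for 3,4-dichlorophenyl gives a 1.0-fold lower number from compound 1 to compound 3 (0.02 log units; within the scatter) in this assay. This extends what the step between compound 1 and compound 2 showed. That step had exchanged only saturated chains, whereas compound 3 shows that a saturated chain carbon bound to a nitrogen on an aromatic ring can carry a six-membered aromatic ring with two chlorine atoms and keep a reading level with compound 1. No available evidence bears on why the reading holds.

The compounds shown leave open whether the chlorine atoms matter, since an unsubstituted benzyl group does not appear among them. They also leave open whether a pyridylmethyl group, or a chain ending in an amine or a carboxylic acid, would be accepted at this nitrogen.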